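The compounds below may be only part of what the source reports. "The series", "measured", "known", "first", "only" and "open" are said of these compounds alone.

Measured in a functional assay on Hs 683 cells (Homo sapiens) for cytotoxicity, read by MTT assay, with a stated time of 72 h; on this read-out lower numbers stand for stronger inhibition and higher numbers for weaker inhibition:

compound 1 `COc1ccc2[nH]c3c4cn[nH]c4c4c(c3c2c1)C(=O)NC4=O`: 45000 nM
compound 2 `Cc1ccc2[nH]c3c4cn[nH]c4c4c(c3c2c1)C(=O)NC4=O`: > 100000 nM, a limit of the assay rather than a number
compound 3 `COc1ccc2[nH]c3c(c4c(c5ccnn53)C(=O)NC4=O)c2c1`: 22000 nM

Compound 2 differs from compound 1 by methyl in place of methoxy on an aromatic carbon. This change gave an at least 2.2-fold higher number from compound 1 to compound 2 (0.34 log units; beyond the scatter); the step is open-ended because of the limit of > 100000 nM in this assay, at which 1 of the 3 values shown sits. Compound 3 is built from the same atoms as compound 1, joined differently; the difference between the two cores is not broken down here. Compound 4 `Cc1ccc2[nH]c3c(c4c(c5ccnn53)C(=O)NC4=O)c2c1` is not yet measured and differs from compound 3 by methyl in place of methoxy on an aromatic carbon, the same change at the same place as that from compound 1 to compound 2. Resting on an at least 2.2-fold higher number from compound 1 to compound 2 (0.34 log units; beyond the scatter), compound 4 is expected to show a 2.7-fold higher number from compound 3 to compound 4 (0.44 log units; beyond the scatter). Compound 4 is therefore estimated at 60000 nM, most likely between 30000 nM and 150000 nM.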

Compound 4, half-maximal inhibitory concentration: 64000 nM
Compound 4: middle estimate off by 1.1-fold (0.03 log units), on the low side, within the range that was stated.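

On the second core, replacing methoxy with methyl again moves the number upward in this assay, with a 2.9-fold higher number from compound 3 to compound 4 (0.46 log units; beyond the scatter), so on both cores shown the change goes in the direction of weaker inhibition. Whether the size of the step also carries over is not settled: the same change on two cores in this assay, an at least 2.2-fold higher number (0.34 log units; beyond the scatter) from compound 1 to compound 2 and a 2.9-fold higher number (0.46 log units; beyond the scatter) from compound 3 to compound 4; the limit leaves it open whether they differ Compound 2 gives > 100000 nM, which is a limit of the assay and not a number.

On these data alone, whether a group such as an amine or a carboxylic acid would give a lower number than methoxy at this place on either core remains open. As far as these compounds go, it also remains open whether the same direction would hold on any core beyond these two.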